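Cyclopentyl for Isopropyl on the Amide Nitrogen

A few compounds are considered here, and "the series" means these few. Any claim that something is new, unique, unknown or untested is made for them only; others in the source may bear on it.

Measured compounds:
compound 1 `CC(C)N1CCc2nc(C#Cc3ccccc3Cl)ccc2C1=O`, 5680 nM
compound 2 `CC(C)N1CCc2nc(C#Cc3cccs3)ccc2C1=O`, 1930 nM

In an assay on HEK293 cells for displacement of a labelled ligand from metabotropic glutamate receptor 5 (Homo sapiens), with a stated time of 2 h (on this read-out lower numbers stand for stronger inhibition and higher numbers for weaker inhibition), compound 1 gives 5680 nM, the highest of the two numbers; its nearest neighbour is compound 2, with a 2.9-fold lower number from compound 1 to compound 2 (0.47 log units; beyond the scatter). That step changes the group on the triple-bonded carbon, not the group on the amide-type nitrogen.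

Compound 3 `O=C1c2ccc(C#Cc3ccccc3Cl)nc2CCN1C1CCCC1` differs from compound 1 in one place: cyclopentyl in place of isopropyl on an amide-type nitrogen in a ring. Among the measured compounds shown here, no measured step touches this position, so the only guide is the value of compound 1 itself. Without a bearing step, the expected change from compound 1 to compound 3 is none beyond the scatter; the estimated step is a 1.1-fold lower number from compound 1 to compound 3 (0.06 log units; within the scatter). Compound 3 is therefore expected to give about 5000 nM in this assay, with a range from 1500 nM to 15000 nM that reflects the lack of any precedent for this change.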

Compound 3, inhibition constant: > 32000 nM
Compound 3: only a limit was reported (the forecaster's own chance of this, stated with the estimate: 10%); middle value at least 6.4-fold (0.80 log units) away from the limit.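

Among the compounds shown here, the only earlier step, a 2.9-fold lower number from compound 1 to compound 2 (0.47 log units; beyond the scatter), changed the group on the triple-bonded carbon, so it said nothing about the amide-type nitrogen. In this assay, this position proves sensitive to the change of group, with cyclopentyl in place of isopropyl giving an at least 5.6-fold higher number from compound 1 to compound 3 (0.75 log units; beyond the scatter). The result for compound 3 is a limit and not a number, so the step has no measured upper end: the limit of > 32000 nM in this assay, at which 1 of the 3 values shown sits.

The compounds shown do not separate the effect of the ring from that of the added carbon atoms, as cyclopentyl brings both in a single change. They also leave open how a methyl group, a longer chain such as n-butyl or a cyclopropyl ring on this nitrogen would read, and whether the same change would give a similar step with thiophen-2-yl on the triple-bonded carbon.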